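Adding an amino group to a second chloromethyl-benzyl purine

The source may report more compounds than this note shows. Statements on the series, on what has been measured and on what is new or still open speak of the compounds shown alone.

Of the compounds shown here, three have been tested in a functional assay on HCT-116 cells (Homo sapiens) for cytotoxicity, read by sulforhodamine B assay, with a stated time of 48 h; a higher number here means a weaker inhibitor of growth, a lower number a stronger inhibitor of growth. Compound 1, `ClCc1ccc(Cn2cnc3c(Cl)ncnc32)cc1`, gives 1120 nM. Compound 2, `Nc1nc(Cl)c2ncn(Cc3ccc(CCl)cc3)c2n1`, differs from compound 1 by one change, (amino in place of hydrogen on an aromatic carbon), and in this assay compound 2 gives 2750 nM. That single change produced a 2.5-fold higher number from compound 1 to compound 2 (0.39 log units; beyond the scatter), so the amino group made growth inhibition weaker in this pair.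

Compound 3, `ClCc1ccccc1Cn1cnc2c(Cl)ncnc21`, has the same atoms as compound 1 joined differently; the difference between the two cores is not broken down here. In this assay compound 3 gives 1900 nM, a number that sits within the usual scatter of both compound 1 and compound 2, so no order among the three can be read from it.

Compound 4, `Nc1nc(Cl)c2ncn(Cc3ccccc3CCl)c2n1`, has not yet been measured. It differs from compound 3 by amino in place of hydrogen on an aromatic carbon. The place of this change is described in exactly the same words as the change from compound 1 to compound 2, so the two changes are the same change made on two different cores. For the measured compounds named here, only one earlier example exists, so the expectation rests on that pair alone. The step is estimated at a 2.5-fold higher number from compound 3 to compound 4 (0.39 log units; beyond the scatter), because the same change earlier produced a 2.5-fold higher number from compound 1 to compound 2 (0.39 log units; beyond the scatter) in this assay. On that basis compound 4 is expected to give about 4700 nM, with a plausible range from 2000 nM to 11000 nM.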

Compound 4, concentration for 50% growth inhibition: 3980 nM
Compound 4: middle estimate off by 1.2-fold (0.07 log units), on the high side; measured number inside the range.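

In this assay, amino in place of hydrogen on an aromatic carbon gives a 2.1-fold higher number from compound 3 to compound 4 (0.32 log units; beyond the scatter) and so weakens growth inhibition on this core, as it did on the core of compound 1. The two steps point the same way and are close in size, so in this small set the change carries from one core to the other with much the same result: the same change on two cores in this assay, a 2.5-fold higher number (0.39 log units; beyond the scatter) from compound 1 to compound 2 and a 2.1-fold higher number (0.32 log units; beyond the scatter) from compound 3 to compound 4, 1.2-fold (0.07 log units) apart, within the scatter of two such steps. For the compounds shown here, this rests on only two pairs of compounds tested in a single cell line, so it shows no general rule for other cores and does not explain why the amino group weakens growth inhibition.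

The compounds shown leave open whether the number depends on amino itself, as a hydroxyl group, a methylamino group or a dimethylamino group on the same aromatic carbon could shift it by a different amount or in the other direction. They also leave open whether the step would stay the same size if the chloromethyl group gave way to a plain methyl group or a hydroxymethyl group, or if the chloro group on the shared core gave way to a methoxy group.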